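The source may report more compounds than this note shows. Statements on the series, on what has been measured and on what is new or still open speak of the compounds shown alone.

Of the compounds shown here, two sharing one core have been tested so far in a functional assay on A549 cells (Homo sapiens) for cytotoxicity, read by MTT assay, with a stated time of 48 h; a lower number here means a stronger inhibitor, a higher number a weaker inhibitor. Compound 1 `COc1cc(C2=NOC(COCc3cn(Cc4cc(C)cnc4Cl)nn3)C2)cc(OC)c1OC` gives 37700 nM, while compound 2 `COc1cc(C2=NOC(COCc3cn(Cc4cc(-c5ccccc5)cnc4Cl)nn3)C2)cc(OC)c1OC` gives 8600 nM, the lower of the two numbers and so the stronger result. Compound 3 `COc1cc(C2=NOC(COCc3cn(Cc4cc(-c5ccc(C)cc5)cnc4Cl)nn3)C2)cc(OC)c1OC` differs from compound 2 at a single place: methyl in place of hydrogen on an aromatic carbon. In words, this is methyl in place of hydrogen on an aromatic carbon, which turns phenyl into 4-methylphenyl.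

Going by the values given here, only one measured step bears on this change, and only indirectly. Replacing methyl with phenyl on an aromatic carbon gave a 4.4-fold lower number from compound 1 to compound 2 (0.64 log units; beyond the scatter), a modest step beyond the scatter. That step swapped a methyl for a whole ring, whereas the new change adds only a methyl to that ring. Among the compounds with values here, no measured pair tests this exact change, so its direction remains open. In this assay, a smaller step is therefore expected, probably none beyond the scatter. The expected step is a 1.1-fold lower number from compound 2 to compound 3 (0.06 log units; within the scatter). For compound 3, the estimated value is 7500 nM, with an expected range of 3000 nM to 19000 nM.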

Compound 3, half-maximal inhibitory concentration: 11500 nM
Estimate against measurement, compound 3: 1.5-fold (0.19 log units) below, within the range that was stated.
By their numbers in this assay, from the lowest: compounds 2 and 3 (each within the scatter of the next); then compound 1.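

In this assay, placing a methyl on the phenyl ring of compound 2, para to a large group, gives a 1.3-fold higher number from compound 2 to compound 3 (0.13 log units; within the scatter), so compound 2 and compound 3 cannot be told apart, and this one-carbon addition has no measurable effect on the reading. The lower number first seen with phenyl also holds when that ring carries the methyl: 4-methylphenyl in place of the original methyl gives a 3.3-fold lower number from compound 1 to compound 3 (0.52 log units; beyond the scatter), a modest step of similar standing to the one seen earlier with plain phenyl. Nothing measured here speaks to the reason behind either step.

Going by these compounds alone, a methyl is only one small group, so it remains open whether something different at this spot on the ring, such as a chlorine atom, an amine or a carboxylic acid, would move the number beyond the scatter in either direction. From the compounds shown here alone, it also remains open whether a methyl on another carbon of the same ring would behave as this one does.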